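A few compounds are considered here, and "the series" means these few. Any claim that something is new, unique, unknown or untested is made for them only; others in the source may bear on it.

In a toxicity assay on MT4 cells (Homo sapiens) for cytotoxicity, read by MTT assay (on this read-out higher numbers stand for lower toxicity in this test and lower numbers for higher toxicity in this test), compound 1 (`Cc1cc(-c2ccc(F)cc2)cc(C)c1Oc1cc(N)nc(Nc2ccc(C#N)cc2)n1`) gives 23100 nM, compound 2 (`Cc1cc(-c2ccc(Cl)cc2)cc(C)c1Oc1cc(N)nc(Nc2ccc(C#N)cc2)n1`) gives 21500 nM and compound 3 (`Cc1ccccc1-c1cc(C)c(Oc2cc(N)nc(Nc3ccc(C#N)cc3)n2)c(C)c1`) gives 25600 nM. These numbers all lie within the scatter of one another, so compound 3 stands level with the other two. Compound 4 (`COc1cccc(-c2cc(C)c(Oc3cc(N)nc(Nc4ccc(C#N)cc4)n3)c(C)c2)c1`) has 3-methoxyphenyl in place of 2-methylphenyl on an aromatic carbon. Three measured steps change the group at this same place: a 1.1-fold lower number from compound 1 to compound 2 (0.03 log units; within the scatter), a 1.1-fold higher number from compound 1 to compound 3 (0.04 log units; within the scatter) and a 1.2-fold higher number from compound 2 to compound 3 (0.08 log units; within the scatter). All three stay within the scatter, although none of them involves a 3-methoxyphenyl group. No change beyond the scatter is therefore expected in this assay, and the expected step is a 1.1-fold lower number from compound 3 to compound 4 (0.05 log units; within the scatter). The estimated value for compound 4 is 23000 nM, within an expected range of 12000 nM to 40000 nM.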

Compound 4, half-maximal cytotoxic concentration: 19300 nM
Compound 4: the middle estimate sits 1.2-fold (0.08 log units) above what was measured; the range from low to high includes it.
By their numbers in this assay, from the lowest: compounds 4, 2, 1 and 3 (each within the scatter of the next).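

In this assay, for the compounds shown here, 3-methoxyphenyl, the first group here with an oxygen and a hydrogen-bond acceptor, stays level with all three earlier groups, with a 1.3-fold lower number from compound 3 to compound 4 (0.12 log units; within the scatter) and a 1.1-fold lower number from compound 2 to compound 4 (0.05 log units; within the scatter) and a 1.2-fold lower number from compound 1 to compound 4 (0.08 log units; within the scatter) on this read-out. Adding that oxygen at this position therefore brings no change beyond the scatter, and all four compounds stand level. Nothing measured here bears on why the numbers stay so close. As far as these compounds go, whether an amine or a carboxylic acid in place of the phenyl group would shift the number remains open.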